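The source may hold more compounds than are shown below. What is called first, only, known or untested is meant among the compounds shown, and "the series" means these compounds.

Working notes on the step from compound 2 to compound 4. Compound 2 `O=C(O)CCCCCCC(=O)Nc1ccc(C2=C(c3ccc(O)cc3)C3CC(S(=O)(=O)Oc4cccc5ccccc45)C2O3)cc1` gives > 100000 nM in an ADME assay on Vero cells (Chlorocebus sabaeus) for inhibition, read by MTT assay, with a stated time of 72 h (a lower number here means a stronger inhibitor, a higher number a weaker inhibitor), which is a limit and not a number. Compound 1 `O=C(O)CCCCCCC(=O)Nc1ccc(C2=C(c3ccc(O)cc3)C3CC(S(=O)(=O)Oc4ccccc4C(F)(F)F)C2O3)cc1` gives > 100000 nM, again a limit. Compound 3 `O=C(O)CCCCCCC(=O)Nc1ccc(C2=C(c3ccc(O)cc3)C3CC(S(=O)(=O)Oc4ccc(C(F)(F)F)cc4)C2O3)cc1` gives > 100000 nM, also a limit. Compound 2 therefore has no readable position in the series, and the evidence is the limit of > 100000 nM in this assay, at which 3 of the 3 values shown sit.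

Compound 4 `O=C(CCCCCCC(=O)Nc1ccc(C2=C(c3ccc(O)cc3)C3CC(S(=O)(=O)Oc4cccc5ccccc45)C2O3)cc1)NO` differs from compound 2 at one place: hydroxyamino in place of hydroxy on a carbonyl carbon. In words, hydroxyamino stands in place of hydroxy on a carbonyl carbon, which turns carboxy into hydroxycarbamoyl.

The measured steps are a step that the two limits leave unreadable from compound 1 to compound 2, a step that the two limits leave unreadable from compound 1 to compound 3 and a step that the two limits leave unreadable from compound 2 to compound 3. All three exchange the group on an oxygen, and none touches the carbonyl end, so they offer no size to carry over to this change. Within the data shown here, no measured compound carries hydroxycarbamoyl. The direction follows only from the ceiling: any readable number for compound 4 in this assay would lie on the stronger side, though it may stay at the limit. The expected change is an at least 3.3-fold lower number from compound 2 to compound 4 (0.52 log units; beyond the scatter), and this estimate is loose. For compound 4 the estimated value is 30000 nM, with an expected range from 5000 nM to 100000 nM.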

Compound 4, half-maximal inhibitory concentration: > 100000 nM
Compound 4 ended at the assay's limit (the forecaster's own chance of this, stated with the estimate: 35%); middle value at least 3.3-fold (0.52 log units) from the limit.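

In this assay compound 4 gives > 100000 nM, which is a limit and not a number. With compound 2 also at a limit, no step can be read between compound 2 and compound 4. The compounds shown leave open whether any structure in this series gives a readable number in this assay.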